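The source may hold more compounds than are shown below. What is called first, only, known or untested is meant among the compounds shown, and "the series" means these compounds.

Measured compounds: compound 1 `COC(Nc1cc(Oc2c(C)cc(/C=C/C#N)cc2C)nc(Nc2ccc(C#N)cc2)n1)OC`, 3470 nM; compound 2 `C=CCNc1cc(Oc2c(C)cc(/C=C/C#N)cc2C)cc(Nc2ccc(C#N)cc2)n1`, 82100 nM; compound 3 `Cc1cc(/C=C/C#N)cc(C)c1Oc1cc(Nc2ccc(C#N)cc2)nc(NC2CC2)c1`, 24800 nM.

In an ADME assay on MT4 cells (Homo sapiens) for cytotoxicity, read by MTT assay, with a stated time of 5 days (on this read-out higher numbers stand for lower toxicity in this test and lower numbers for higher toxicity in this test), compound 1 gives the lowest of the three numbers, so it is the most cytotoxic of the set. Going by the values given here, compound 3 sits nearer to it than compound 2, and the only step between measured compounds, a 3.3-fold lower number from compound 2 to compound 3 (0.52 log units; beyond the scatter), is seen on the core of compound 2, which differs from that of compound 1. Compound 4 `Cc1cc(/C=C/C#N)cc(C)c1Oc1cc(Cl)nc(Nc2ccc(C#N)cc2)n1` is derived from compound 1 by the change (one chlorine atom in place of a group of 6 heavy atoms (3 carbon, 1 nitrogen, 2 oxygen; no ring), on an aromatic carbon). Among the compounds with values here, no measured pair changes the group at this place of the shared core, and the step from compound 2 to compound 3 concerns a substituent on a nitrogen rather than a ring carbon, so it bears only distantly on the case. The shift from a group with a hydrogen-bond donor and three acceptors to a bare chloro is sizeable, so a step beyond the scatter in either direction is plausible, with little ground to favour one side. The expectation for compound 4 is a modest rise, a 2.0-fold higher number from compound 1 to compound 4 (0.30 log units; within the scatter), and its estimated value in this assay is 7000 nM, from 1500 nM to 35000 nM.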

Compound 4, half-maximal cytotoxic concentration: 4310 nM
For compound 4 the middle estimate is 1.6-fold (0.21 log units) above the measured one, within the range that was stated.
By their numbers in this assay, from the lowest: compounds 1 and 4 (each within the scatter of the next); then compound 3; then compound 2.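

In this assay, going by these compounds alone, this is the first measured pair that changes the group at this aromatic carbon of the shared core, and it gives a 1.2-fold higher number from compound 1 to compound 4 (0.09 log units; within the scatter). Compound 4 carries chloro, with no hydrogen-bond donors or acceptors, where compound 1 carries a group of 6 heavy atoms with both, yet their values lie within the scatter of each other, so this large change in the group shows no measurable effect on the read-out in this pair. Nothing available explains why the two groups read alike.

Going by these compounds, it remains open whether a carboxylic acid, a morpholine or a longer alkyl chain at this place would also stay within the scatter of compound 1. On these data alone, the same chloro exchange also remains unknown on the core of compound 2.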